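A few compounds are considered here, and "the series" means these few. Any claim that something is new, unique, unknown or untested is made for them only; others in the source may bear on it.

Measured compounds in a functional assay on DLD-1 cells (Homo sapiens) for cytotoxicity, read by colorimetric assay and MTT assay, with a stated time of 3 days, tested at 20 uM; on this read-out lower numbers stand for a stronger effect and higher numbers for a weaker effect at the one concentration tested:
- compound 1, `COc1ccc(-c2nc(-c3ccccc3)c(-c3ccc4c(c3)NC(=O)CO4)[nH]2)cc1`: 19.1%
- compound 2, `O=C1COc2ccc(-c3[nH]c(-c4c[nH]c5ncccc45)nc3-c3ccccc3)cc2N1`: 53.5%

Compound 2 stands highest of the two numbers in this assay; its nearest neighbour is compound 1, and the step of a number 34.4 percentage points higher from compound 1 to compound 2 (beyond the scatter) lies beyond the scatter. Of the two, compound 1 therefore shows the stronger effect at the one concentration tested.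

Compound 3, `O=C1COc2ccc(-c3[nH]c(-c4ccccc4)nc3-c3ccccc3)cc2N1`, is not yet measured in this assay. It differs from compound 2 in one place: a group of 6 heavy atoms (6 carbon; one six-membered aromatic ring of carbon only) in place of a group of 9 heavy atoms (7 carbon, 2 nitrogen; one five-membered aromatic ring with 1 hetero atom, one six-membered aromatic ring with 1 hetero atom), on an aromatic carbon. The change is a shortening at the same position on the shared core that was varied between compound 1 and compound 2.

Among the compounds with values here, the only step that bears on this is a number 34.4 percentage points higher from compound 1 to compound 2 (beyond the scatter), a large rise in the read-out when the 9-atom group replaces the methoxy-bearing 8-atom group. Compound 3 carries a plain phenyl at that position, which is nearer to the group of compound 1 than to that of compound 2. A step back towards the value of compound 1 is therefore expected, a number 21.5 percentage points lower from compound 2 to compound 3 (beyond the scatter), without assuming the full return.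

Compound 3 is estimated at 32% in this assay, with a range from 14% to 52%.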

Compound 3, a percentage reported as activity, at one concentration (the size of the read-out at that concentration, not a potency): 47.3%
The estimate for compound 3 lay 15.3 percentage points below the measured number; the measured number falls inside the stated range.
By their numbers in this assay, from the lowest: compound 1; then compounds 3 and 2 (each within the scatter of the next).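

In this assay, the step of a number 6.2 percentage points lower from compound 2 to compound 3 (within the scatter) shows that this carbon of the five-membered aromatic ring with 2 nitrogen tolerates an exchange of the larger 9-atom group, with its two rings and its ring nitrogens, for phenyl with no readable change, so the two groups are not separated by this read-out. The step of a number 28.2 percentage points higher from compound 1 to compound 3 (beyond the scatter) adds what the first pair could not show: a single change, hydrogen in place of methoxy on an aromatic carbon, is enough on its own to give a shift beyond the scatter, and compound 1 alone of the three stands apart from the others. No measurement at hand offers a reason for the difference made by the methoxy group.

From the compounds shown here alone, whether this difference is particular to methoxy stays open, since a hydroxy, ethoxy or dimethylamino group, or a fluorine, on the same aromatic carbon would test how much of it depends on the oxygen and the methyl. Going by these compounds, it is also open whether methoxy on the 9-atom group would give a comparable step.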